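A few compounds are considered here, and "the series" means these few. Any claim that something is new, unique, unknown or untested is made for them only; others in the source may bear on it.

In a functional assay on HFF cells (Homo sapiens) for cytotoxicity (a higher number here means a weaker inhibitor, a lower number a stronger inhibitor), compound 1 `CSc1nc(Cl)c2ccn(COCCO)c2n1` gives 30000 nM. Compound 2 `Nc1ncnc2c1ccn2COCCO` reaches only the limit of the assay, > 100000 nM, so no number places it. Its standing is therefore (the limit of > 100000 nM in this assay, at which 1 of the 2 values shown sits), a ceiling rather than a measured point. Compound 3 `Nc1nc(Cl)nc2c1ccn2COCCO` carries chloro in place of hydrogen on an aromatic carbon. Among the compounds with values here, no measured pair shows this single change, so its size can only be estimated; a modest gain in potency is expected, an at least 1.6-fold lower number from compound 2 to compound 3 (0.22 log units; that floor lies within the scatter), though the assay may again report only a limit. For compound 3 the expected half-maximal inhibitory concentration is 60000 nM, within 20000 nM to 150000 nM.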

Compound 3, half-maximal inhibitory concentration: > 100000 nM
Compound 3 was reported as a limit; the forecaster's own chance of this, stated with the estimate: 50%; middle value at least 1.6-fold (0.22 log units) from the limit.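

Within the data shown here, compound 3 gives > 100000 nM in this assay, a limit and not a number, and compound 2 also stands at a limit, so no step between them can be read. As far as these compounds go, whether chloro in place of hydrogen shifts the value at all stays open.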